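The compounds below may be only part of what the source reports. "The series", "measured", "known", "first", "only" and "open" are said of these compounds alone.

Measured so far:
- compound 1, `Cc1ccc(S(=O)(=O)/N=C(/CCNC2=CC(=O)c3ccccc3C2=O)Nc2ccccc2[N+](=O)[O-])cc1`: 5010 nM
- compound 2, `Cc1ccc(S(=O)(=O)/N=C(/CCNC2=CC(=O)c3ccccc3C2=O)Nc2cccc(C(F)(F)F)c2)cc1`: 78500 nM

In a functional assay on A549 cells (Homo sapiens) for cytotoxicity, read by MTT assay, with a stated time of 48 h (a higher number here means a weaker inhibitor, a lower number a stronger inhibitor), compound 1 gives 5010 nM and compound 2 gives 78500 nM. For the measured compounds named here, compound 2 stands highest of the two numbers; the only step seen, a 16-fold higher number from compound 1 to compound 2 (1.20 log units; beyond the scatter), changes nothing but the aryl group on the amine nitrogen and is large, so this position is evidently sensitive.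

Compound 3, `COc1ccc(N/C(CCNC2=CC(=O)c3ccccc3C2=O)=N\S(=O)(=O)c2ccc(C)cc2)c(OC)c1`, has not yet been measured. It differs from compound 2 in one place: 2,4-dimethoxyphenyl in place of 3-(trifluoromethyl)phenyl on an amine nitrogen. The step from compound 1 to compound 2 is the only one that bears on this change, and it was large; a step of comparable size is therefore plausible here too, but its direction cannot be read from two aryl groups alone. Taking the two measured values as the likely span, compound 3 is expected to land between them, nearer the middle, with a 3.9-fold lower number from compound 2 to compound 3 (0.59 log units; beyond the scatter). The estimate for compound 3 is 20000 nM, within 5000 nM to 80000 nM.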

Compound 3, half-maximal inhibitory concentration: 126000 nM
Compound 3: middle estimate off by 6.3-fold (0.80 log units), on the low side; measured number above the stated range.
By their numbers in this assay, from the lowest: compound 1; then compounds 2 and 3 (each within the scatter of the next).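

In this assay, 2,4-dimethoxyphenyl in place of 3-(trifluoromethyl)phenyl on the amine nitrogen gives a 1.6-fold higher number from compound 2 to compound 3 (0.21 log units; within the scatter), so these two aryl groups cannot be told apart here, although only the entering group carries hydrogen-bond acceptors. The sensitivity seen at this position now rests on compound 1 alone: a 25-fold higher number from compound 1 to compound 3 (1.40 log units; beyond the scatter) shows that the 2-nitrophenyl compound stands apart from both other compounds, which adds a second aryl group to the single earlier contrast. No measurement available bears on why the 2-nitrophenyl group separates from the other two.

Still open, going by these compounds, is whether the lower number of compound 1 belongs to the nitro group itself or to the aryl group as a whole. An unsubstituted phenyl group, or a nitrile on the ring in place of the nitro group, would help separate these two readings.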